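From Chloro to a Tert-Butylcarbonyloxy Group on the Shared Core

The compounds below may be only part of what the source reports. "The series", "measured", "known", "first", "only" and "open" are said of these compounds alone.

Compound 2 `Clc1ccc(/C=C2\CCCN=C2c2cccnc2)cc1` is the point of departure. For the measured compounds named here, in an assay on membranes from brain for displacement of a labelled ligand from Neuronal acetylcholine receptor; alpha4/beta2 (Rattus norvegicus), with a stated time of 3 h (on this read-out higher numbers stand for weaker inhibition and lower numbers for stronger inhibition), compound 2 gives 970 nM, the lowest of the two numbers measured so far. Going by the values given here, its only measured neighbour is compound 1 `CC(C)(C)Oc1ccc(/C=C2\CCCN=C2c2cccnc2)cc1`, which in this assay gives 2170 nM. Among the compounds with values here, the single measured step, a 2.2-fold lower number from compound 1 to compound 2 (0.35 log units; beyond the scatter), traces the exchange of tert-butoxy for chloro on the same aromatic carbon of the shared core.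

Compound 3 `CC(C)(C)C(=O)Oc1ccc(/C=C2\CCCN=C2c2cccnc2)cc1` has not yet been measured. It differs from compound 2 in one place: ((tert-butyl)carbonyl)oxy in place of chloro on an aromatic carbon. The entering group, like the tert-butoxy of compound 1, is attached to the ring through oxygen and carries a tert-butyl, so the step that bears on it is a 2.2-fold lower number from compound 1 to compound 2 (0.35 log units; beyond the scatter) read in reverse, with the reservation that compound 3 adds a carbonyl that neither measured compound has. A modest rise in the number, roughly the size of that measured step, is therefore expected, a 2.1-fold higher number from compound 2 to compound 3 (0.31 log units; beyond the scatter). For compound 3 the estimate in this assay is 2000 nM, with a range from 700 nM to 6000 nM.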

Compound 3, inhibition constant: 830 nM
The estimate for compound 3 lay 2.4-fold (0.38 log units) above the measured number, and the stated range covers the measured number.
By their numbers in this assay, from the lowest: compounds 3 and 2 (each within the scatter of the next); then compound 1.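

In this assay there is a 1.2-fold lower number from compound 2 to compound 3 (0.07 log units; within the scatter) and so, at this aromatic carbon para to a large group, chloro and ((tert-butyl)carbonyl)oxy, a group of 7 heavy atoms, cannot be told apart on this read-out. The earlier compounds shown here offered one comparison at this position, and the new one is more specific: a 2.6-fold lower number from compound 1 to compound 3 (0.42 log units; beyond the scatter) separates two groups that both reach the ring through oxygen and both carry a tert-butyl, leaving the carbonyl as the one difference between them. No measurement shown explains why the carbonyl goes with this shift or why the two very different groups of compound 2 and compound 3 give numbers within the scatter of each other.

As far as these compounds go, what a free hydroxyl, an amine or a carboxylic acid on this aromatic carbon would give remains open, as does whether a shorter acyl group such as acetyl would match the tert-butyl version. The three compounds also vary in this one place only, so they say nothing about how the same exchanges would read elsewhere on the shared core or in any other assay.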